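Phenyl ring substituents in a thiosemicarbazone growth-inhibitor series

This account rests on a few compounds, and the source may have more. Where it says the series, first, only, none or still open, it means among the compounds named here.

Measured so far:
compound 1 `CC1=CC[C@@H]([C@@](C)(O)CCCC(C)(C)NC(=S)N/N=C\c2ccccc2)CC1`: 12900 nM
compound 2 `COc1ccc(/C=N\NC(=S)NC(C)(C)CCC[C@](C)(O)[C@@H]2CC=C(C)CC2)cc1`: 15800 nM

In a functional assay on OVCAR-3 cells (Homo sapiens) for cytotoxicity, read by sulforhodamine B assay (on this read-out lower numbers stand for stronger inhibition of growth and higher numbers for weaker inhibition of growth), compound 1 gives 12900 nM and compound 2 gives 15800 nM. Compound 2 stands at the higher of the two numbers, yet the step of a 1.2-fold higher number from compound 1 to compound 2 (0.09 log units; within the scatter) lies within the scatter, so the two compounds do not separate on this read-out.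

Compound 3 `CC1=CC[C@@H]([C@@](C)(O)CCCC(C)(C)NC(=S)N/N=C\c2ccc(O)cc2)CC1` differs from compound 2 by hydrogen in place of methyl on an oxygen on an aromatic ring. Going by the values given here, no measured pair covers the methoxy-to-hydroxy exchange itself; the only step that bears on the same aromatic carbon is a 1.2-fold higher number from compound 1 to compound 2 (0.09 log units; within the scatter), where adding methoxy left the number within the scatter. On that basis a step of a 1.1-fold lower number from compound 2 to compound 3 (0.05 log units; within the scatter) is expected, with no movement beyond the scatter in either direction. For compound 3 the estimate in this assay is 14000 nM, with a range of 6000 nM to 35000 nM.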

Compound 3, concentration for total growth inhibition: 17400 nM
The estimate for compound 3 lay 1.2-fold (0.09 log units) below the measured number; the measured number falls inside the stated range.
By their numbers in this assay, from the lowest: compounds 1, 2 and 3 (each within the scatter of the next).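

Hydroxy at this aromatic carbon adds a third substituent to the comparison: in this assay the exchange of methoxy for hydroxy gives a 1.1-fold higher number from compound 2 to compound 3 (0.04 log units; within the scatter), and hydroxy in place of hydrogen gives a 1.3-fold higher number from compound 1 to compound 3 (0.13 log units; within the scatter). Whether the oxygen carries a methyl or a hydrogen therefore does not separate the compounds, and hydrogen, methoxy and hydroxy at this carbon all remain within the scatter of one another, so no substituent order can be drawn among the three. No independent data are available to explain this lack of separation.

Still open, on these data alone, is whether a group of another kind at this carbon, such as an amine, a carboxylic acid or a nitro group, would move the number beyond the scatter. The compounds shown also leave open how changes elsewhere in the shared core would read out.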